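Sulfonamide variation on a hydroxamate series

A few compounds are considered here, and "the series" means these few. Any claim that something is new, unique, unknown or untested is made for them only; others in the source may bear on it.

The series is followed in an assay for inhibition of histone deacetylase 4 (Homo sapiens), read by fluorescence, with a stated time of 3 h; on this read-out higher numbers stand for an effect only at larger amounts of compound and lower numbers for an effect already at smaller amounts. Within the data shown here, compound 1 `O=C(/C=C/c1cccc(S(=O)(=O)Nc2cccc(F)c2)c1)NO` gives 65 nM, the lowest of the two numbers so far. Compound 3 `COc1ccc(N2CCN(S(=O)(=O)c3cccc(/C=C/C(=O)NO)c3)CC2)cc1` gives 870 nM, a higher number than compound 1 by a gap beyond the usual scatter; compound 3 differs from compound 1 in more than one place, so the two values are only set side by side here. For compound 2 `O=C(/C=C/c1cccc(S(=O)(=O)N2CCN(c3ccccn3)CC2)c1)NO` the entry in this assay reads "not determined" (no result reported), so no number is available for it.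

Compound 4 `COc1ccc(NS(=O)(=O)c2cccc(/C=C/C(=O)NO)c2)cc1` is not yet measured. It differs from compound 1 as follows: 4-methoxyphenyl in place of 3-fluorophenyl on a sulfonamide nitrogen. Among the measured compounds shown here, no step between measured compounds isolates this change. The 4-methoxyphenyl group is shared with compound 3, but compound 3 also carries the piperazine, so its value of 870 nM cannot be read as the effect of the aryl group alone.

For compound 4 a small step toward a higher number than compound 1 is expected, a 2.3-fold higher number from compound 1 to compound 4 (0.36 log units; beyond the scatter), staying close to the scatter. Compound 4 is estimated at 150 nM, within 50 nM to 450 nM.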

Compound 4, concentration for half-maximal effect: 33 nM
Estimate against measurement, compound 4: 4.5-fold (0.66 log units) above; measured number below the stated range.
By their numbers in this assay, from the lowest: compounds 4 and 1 (each within the scatter of the next); then compound 3.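

Among these compounds, on the sulfonamide nitrogen whose other neighbour is the sulfonyl sulfur, this is the first change that can be read in isolation: in this assay, 4-methoxyphenyl in place of 3-fluorophenyl gives a 2.0-fold lower number from compound 1 to compound 4 (0.29 log units; within the scatter). The 4-methoxyphenyl group brings a hydrogen-bond acceptor that the 3-fluorophenyl group lacks, yet the two compounds are not separated on this read-out. Nothing measured here speaks to why these two aryl groups read alike.

The compounds shown leave open whether a saturated ring such as cyclohexyl, or a phenyl ring carrying an amine or a carboxylic acid, would hold a similar value on this nitrogen. This step also swaps the ring substituent and its numbered place together, and the compounds shown do not separate the two.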